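A few compounds are considered here, and "the series" means these few. Any claim that something is new, unique, unknown or untested is made for them only; others in the source may bear on it.

Measured compounds:
compound 1, `CCCCCCCCCCCCCCC1(C(=O)OCC(O)CO)CO1`: 5 mg/kg
compound 2, `CCCCCCCCCCCCCCCCCCCCCCC1(C(=O)OC)CO1`: 10 mg/kg
compound 3, `CCCCCCCCCCCCCCCCCCC1(C(=O)OC)CO1`: 10 mg/kg

Of the compounds shown here, three sharing the core of compound 1 have been measured in a functional assay on the whole organism with Rattus norvegicus as the target, in the glucose tolerance test; on this read-out higher numbers stand for an effect only at larger amounts of compound and lower numbers for an effect already at smaller amounts. Compound 1 gives 5 mg/kg, compound 2 gives 10 mg/kg and compound 3 gives 10 mg/kg. Compound 1 carries the smallest number of the three, yet compound 2 and compound 3 each stand within the scatter of it, so no order among the three can be drawn. Among the compounds with values here, the single step between close neighbours, no change at the digits printed from compound 2 to compound 3 (within the scatter), shows that the length of the chain leaves the read-out where it was.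

Compound 4, `CCCCCCCCCCCCCCC1(C(=O)N(C)C)CO1`, has not yet been measured. It differs from compound 1 in one place: dimethylamino in place of 2,3-dihydroxypropoxy on a carbonyl carbon. Within the data shown here, no measured pair shows this kind of change at the carbonyl carbon, so nothing bears on it directly; the step from compound 2 to compound 3 concerns the chain alone. Among the measured compounds shown here, compound 1 on the one hand and compound 2 and compound 3 with their other ester group on the other lie within the scatter of each other. The author therefore expects for compound 4 a step of a 2.0-fold higher number from compound 1 to compound 4 (0.30 log units; within the scatter), leaning toward a larger dose or none beyond the scatter. The estimate for compound 4 in this assay is 10 mg/kg, with a range from 3 mg/kg to 30 mg/kg.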

Compound 4, minimum effective dose: 25 mg/kg
For compound 4 the middle estimate is 2.5-fold (0.40 log units) below the measured one; the measured number falls inside the stated range.
By their numbers in this assay, from the lowest: compounds 1, 2 and 3 (each within the scatter of the next); then compound 4.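

In this assay, the change on the carbonyl carbon moves the read-out beyond the scatter, with dimethylamino in place of 2,3-dihydroxypropoxy giving a 5.0-fold higher number from compound 1 to compound 4 (0.70 log units; beyond the scatter) as the one step of this size among the compounds shown. Within the data shown here, the earlier step concerned the chain alone and stayed within the scatter, so this position on the carbonyl carbon, whose other neighbour is a saturated ring carbon, is the first place where a single change is seen to matter, and (2,3-dihydroxypropoxy)carbonyl is the better of the two groups compared here. Nothing measured explains the step, and it remains unknown which part of the exchange, from a group with 2 hydrogen-bond donors and 3 acceptors to one with none, is responsible.

The compounds shown leave open whether a 2-hydroxyethylamino or 2,3-dihydroxypropylamino group, which would keep the hydroxyl groups while nitrogen stays on the carbonyl carbon, would stay close to compound 1 or to compound 4. They also leave open how a carboxylic acid at this carbon would read, and whether the dimethylcarbamoyl group would give the same step on a longer chain.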